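Working notes on a para-substituent swap toward compound 4

The source may report more compounds than this note shows. Statements on the series, on what has been measured and on what is new or still open speak of the compounds shown alone.

Measured so far in an assay on isolated protein for inhibition of steroid 17-alpha-hydroxylase/17,20 lyase (Homo sapiens), tested at 2.5 uM; on this read-out lower numbers stand for less inhibition and higher numbers for more inhibition at the one concentration tested (going by the name of the read-out):
- Compound 1, `COc1ccc2c(=O)c(Cn3ccnc3)c(-c3ccc([N+](=O)[O-])cc3)oc2c1`: compound 1 gives 9%
- Compound 2, `COc1ccc2c(=O)c(Cn3ccnc3)c(-c3ccc(Br)cc3)oc2c1`: compound 2 gives 29%
- Compound 3, `O=c1c(Cn2ccnc2)c(-c2ccc(Br)cc2)oc2ccccc12`: compound 3 gives 27%

Compound 3 stands second highest of the three numbers. The step of a number 2 percentage points lower from compound 2 to compound 3 (within the scatter) lies within the scatter, so compound 2 and compound 3 cannot be ordered. Its gap to compound 1 lies beyond the scatter, with compound 3 the higher of the two.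

Compound 4, `COc1ccc(-c2oc3ccccc3c(=O)c2Cn2ccnc2)cc1`, differs from compound 3 as follows: methoxy in place of bromo on an aromatic carbon.

Among the measured compounds shown here, only one measured step concerns this same place on the aryl ring: from compound 1 to compound 2 the change was a number 20 percentage points higher from compound 1 to compound 2 (beyond the scatter), a modest shift. The other step, a number 2 percentage points lower from compound 2 to compound 3 (within the scatter), concerns the methoxy at another place and stays within the scatter. For the measured compounds named here, no measured pair sets bromo against methoxy at this place, so the direction of the new step is not fixed by the series.

Expected: a modest step, more likely downward than upward, given that the only prior move at this place was a number 20 percentage points higher from compound 1 to compound 2 (beyond the scatter) and that the nitro-bearing compound 1 sits lowest; the estimated step is a number 7 percentage points lower from compound 3 to compound 4 (within the scatter). Compound 4 is estimated at 20%, within 5% to 38%.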

Compound 4, a percentage reported as inhibition, at one concentration (the size of the read-out at that concentration, not a potency): 26%
Compound 4: the middle estimate sits 6 percentage points below what was measured; low and high end bracket the measured number.
By their numbers in this assay, from the lowest: compound 1; then compounds 4, 3 and 2 (each within the scatter of the next).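

In this assay, the change from 4-bromophenyl to 4-methoxyphenyl gives a number 1 percentage points lower from compound 3 to compound 4 (within the scatter), so this pair gives no ground for ordering bromo and methoxy at this place on the aryl ring. Of the two steps at this place, only a number 20 percentage points higher from compound 1 to compound 2 (beyond the scatter) lies beyond the scatter, which sets nitro apart from bromo on the methoxy-bearing core, whereas methoxy is not set apart from bromo on the core without that methoxy. No measurement at hand offers an explanation for either step.

From the compounds shown here alone, it remains open whether the same bromo-to-methoxy change would also stay within the scatter on the methoxy-bearing core, and whether an amine, a carboxylic acid or a longer alkoxy chain at this place would shift the number in either direction. With a single test concentration in this assay, these readings also leave open how the compounds would compare across a range of concentrations, so the present numbers give no potency ranking for compound 3 and compound 4.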